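From 2-methoxyphenyl to 3-fluorophenyl in compound 4

The source may report more compounds than this note shows. Statements on the series, on what has been measured and on what is new or still open speak of the compounds shown alone.

Compound 1 `CN1CCN(c2ccc(S(=O)(=O)Oc3cccc(F)c3)cc2)C1=O`: > 100000 nM, a limit
Compound 2 `CCN1CCN(c2ccc(S(=O)(=O)Oc3ccccc3OC)cc2)C1=O`: > 100000 nM, a limit
Compound 3 `CCCN1CCN(c2ccc(S(=O)(=O)Oc3ccccc3OC)cc2)C1=O`: 13000 nM

In a functional assay on MCF7 cells (Homo sapiens) for antiproliferative activity, read by sulforhodamine B assay, with a stated time of 48 h (on this read-out lower numbers stand for stronger inhibition and higher numbers for weaker inhibition), compound 3 alone gives a real number, 13000 nM. Compound 1 and compound 2 give no number, only (the limit of > 100000 nM in this assay, at which 2 of the 3 values shown sit). Compound 4 `CCCN1CCN(c2ccc(S(=O)(=O)Oc3cccc(F)c3)cc2)C1=O` differs from compound 3 by 3-fluorophenyl in place of 2-methoxyphenyl on an oxygen, with 3-fluorophenyl in place of 2-methoxyphenyl on an oxygen. Among the measured compounds shown here, the one measured step, an at least 7.6-fold lower number from compound 2 to compound 3 (0.88 log units; beyond the scatter), changes the chain and leaves this group alone, so it sets no size for this swap. Compound 1 carries the 3-fluorophenyl but offers only its limit. With no measured guide to size or direction, the expected change is a 1.2-fold higher number from compound 3 to compound 4 (0.06 log units; within the scatter), which is not expected to exceed the scatter. Compound 4 is estimated at 15000 nM, within an expected range of 4000 nM to 70000 nM.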

Compound 4, half-maximal inhibitory concentration: 24000 nM
Beside the measured number, compound 4's estimate is 1.6-fold (0.20 log units) below it, and the stated range covers the measured number.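

In this assay the swap on the oxygen gives a 1.8-fold higher number from compound 3 to compound 4 (0.27 log units; within the scatter), so a measurable number does not depend on the 2-methoxyphenyl group. The chain matters with 3-fluorophenyl as well, with an at least 4.1-fold lower number from compound 1 to compound 4 (0.61 log units; beyond the scatter), a gain that the step from compound 2 to compound 3 showed only with 2-methoxyphenyl. Compound 1 stands at a limit, not a number: the limit of > 100000 nM in this assay, at which 2 of the 4 values shown sit.

Going by these compounds, what a longer chain such as butyl would do stays open. So does the effect of an amine or a carboxylic acid in place of the fluorine.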